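This account rests on a few compounds, and the source may have more. Where it says the series, first, only, none or still open, it means among the compounds named here.

Four compounds share one core, a chroman carrying a long unsaturated chain, and differ only at the carbamate end. Compound 1 `CC(C)=CCC/C(C)=C/CC/C(C)=C/CC[C@]1(C)CCc2cc(OC(=O)NS(=O)(=O)c3ccc(C)cc3)c(C)c(C)c2O1` and compound 2 `CC(C)=CCC/C(C)=C/CC/C(C)=C/CC[C@]1(C)CCc2cc(OC(=O)NS(=O)(=O)c3ccccc3)c(C)c(C)c2O1` carry sulfonyl carbamates. In a functional assay on MDA-MB-231 cells (Homo sapiens) for antiproliferative activity, read by MTT assay, with a stated time of 96 h (a higher number here means a weaker inhibitor, a lower number a stronger inhibitor), compound 1 reaches only the limit of the assay at > 10000 nM. In this assay compound 2 likewise sits at the limit, > 10000 nM. The change between them, (methyl in place of hydrogen on an aromatic carbon), therefore gives a step that the two limits leave unreadable from compound 2 to compound 1, since the limit of > 10000 nM in this assay, at which 2 of the 3 values shown sit, holds both values.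

Compound 3 `CC(C)=CCC/C(C)=C/CC/C(C)=C/CC[C@]1(C)CCc2cc(OC(=O)NC(=O)Oc3ccccc3)c(C)c(C)c2O1` replaces the sulfonyl by a carbonate, the difference being (phenoxycarbonyl in place of phenylsulfonyl on an amide-type nitrogen). In this assay compound 3 gives "not determined" (no result reported), so no result was reported for it. Compound 4 `CC(C)=CCC/C(C)=C/CC/C(C)=C/CC[C@]1(C)CCc2c(C)c(OC(=O)NC(=O)Oc3ccccc3)c(C)c(C)c2O1` differs from compound 3 by methyl in place of hydrogen on an aromatic carbon. This is the same kind of change as that from compound 2 to compound 1, a methyl for a hydrogen on an aromatic carbon, but not the same: in compound 1 the methyl sits on the phenyl ring para to a large group, whereas in compound 4 it sits on the fused core ring, ortho to a fused ring and ortho to a large group, meta to a fused ring and to a methyl group, and para to a methyl group.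

The size of the step from compound 3 to compound 4 in this assay cannot be stated as a number, as compound 3 has no number and the earlier methyl step reads a step that the two limits leave unreadable from compound 2 to compound 1. With compound 1 at > 10000 nM and compound 2 at > 10000 nM, both at the limit, compound 4 is expected to lie near 15000 nM, estimated between 3000 nM and 60000 nM, most likely again reported only as a limit.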

Compound 4, half-maximal inhibitory concentration: > 10000 nM
Compound 4: a limit, no number; the forecaster's own chance of this, stated with the estimate: 70%; the middle value lies beyond the limit too.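

In this assay, among these compounds, compound 4 gives > 10000 nM, a limit and not a number, and with compound 3 offering no value, no step from compound 3 to compound 4 can be read. Compound 4 joins compound 1 and compound 2 at the same limit: the limit of > 10000 nM in this assay, at which 3 of the 4 values shown sit.

The compounds shown leave open whether either methyl change, or the change at the carbamate end, alters activity in this assay at all.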